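The source may hold more compounds than are shown below. What is called first, only, known or untested is meant among the compounds shown, and "the series" means these compounds.

Compound 2 `ClCc1ccccc1Cn1cnc2c(Cl)nc(Cl)nc21` carries two chloro groups on its fused core and a chloromethyl group on the benzyl ring. In a functional assay on MDA-MB-435 cells (Homo sapiens) for cytotoxicity, read by sulforhodamine B assay, with a stated time of 48 h (on this read-out lower numbers stand for stronger inhibition of growth and higher numbers for weaker inhibition of growth), compound 2 gives 1620 nM. Compound 1 `ClCc1ccc(Cn2cnc3c(Cl)ncnc32)cc1`, which differs in more than one place, in this assay gives 1620 nM, so the two values stand level and no difference within the scatter can be read from them. Compound 3 `ClCc1ccccc1Cn1cnc2c(Cl)ncnc21` is yet to be measured in this assay. From compound 2 to compound 3 the change is hydrogen in place of chloro on an aromatic carbon, a hydrogen in place of chloro on an aromatic carbon. Since compound 1, with a single chloro on the same fused core, gives 1620 nM, the second chloro appears to add little, and the step of a 1.2-fold higher number from compound 2 to compound 3 (0.09 log units; within the scatter) is expected to be small, if anything toward weaker inhibition. Compound 3 is therefore estimated at 2000 nM, with a range from 700 nM to 6000 nM.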

Compound 3, concentration for 50% growth inhibition: 3020 nM
Estimate against measurement, compound 3: 1.5-fold (0.18 log units) below; the range from low to high includes it.
By their numbers in this assay, from the lowest: compounds 1, 2 and 3 (each within the scatter of the next).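

Among these compounds, replacing the chloro group between two ring nitrogen atoms with hydrogen gives, in this assay, a 1.9-fold higher number from compound 2 to compound 3 (0.27 log units; within the scatter), and this is the first comparison that isolates this position, since compound 1 differs from compound 2 in more than one place. The step stays within the scatter, so these two compounds do not show that the chloro group at this position affects growth inhibition in these cells. No evidence is available that would explain the size of this step.

The compounds shown leave open whether a different group at this position, such as an amine or a methoxy group, would shift the number beyond the scatter. They also leave open how compound 3 would respond if its chloromethyl group gave way to a plain methyl or a hydroxymethyl group.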